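Methyl on the furan of compound 3

The compounds below may be only part of what the source reports. "The series", "measured", "known", "first", "only" and "open" are said of these compounds alone.

Measured compounds:
- compound 1, `N#CC1=C(N)N(c2ccc(S(N)(=O)=O)cc2)C2=C(C(=O)CCC2)C1c1ccc(O)cc1`: 100%
- compound 2, `N#CC1=C(N)N(c2ccc(S(N)(=O)=O)cc2)C2=C(C(=O)CCC2)C1c1ccc(Cl)cc1Cl`: 95%
- compound 3, `N#CC1=C(N)N(c2ccc(S(N)(=O)=O)cc2)C2=C(C(=O)CCC2)C1c1ccco1`: 10%

In a functional assay on Ehrlich cells (Mus musculus) for antiproliferative activity, read by trypan blue exclusion, with a stated time of 2 h, tested at 100 ug/mL (on this read-out lower numbers stand for a weaker effect and higher numbers for a stronger effect at the one concentration tested), compound 1 gives 100% and compound 2 gives 95%; the two lie within the scatter of each other, a number 5 percentage points lower from compound 1 to compound 2 (within the scatter). Compound 3 stands lowest of the three numbers: the nearest is compound 2, a number 85 percentage points lower from compound 2 to compound 3 (beyond the scatter), and the furthest is compound 1, a number 90 percentage points lower from compound 1 to compound 3 (beyond the scatter). Both steps are large and beyond the scatter.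

Compound 4, `Cc1ccoc1C1C(C#N)=C(N)N(c2ccc(S(N)(=O)=O)cc2)C2=C1C(=O)CCC2`, differs from compound 3 only in methyl in place of hydrogen on an aromatic carbon. Among the compounds with values here, no measured step changes a substituent on the furan-2-yl group; the two steps that reach compound 3 swap the whole group on the saturated ring carbon, and they show that compound 3 already sits at the low end. With nothing in the data that moves a furan-2-yl compound upward, compound 4 is expected to stay close to compound 3, with a step of a number 5 percentage points higher from compound 3 to compound 4 (within the scatter), not beyond the scatter. For compound 4 the estimate in this assay is 15%, between 0% and 40%.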

Compound 4, a percentage reported as activity, at one concentration (the size of the read-out at that concentration, not a potency): 45%
For compound 4 the middle estimate is 30 percentage points below the measured one; measured number above the stated range.
By their numbers in this assay, from the lowest: compound 3; then compound 4; then compounds 2 and 1 (each within the scatter of the next).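

In this assay, within the data shown here, a single methyl in place of hydrogen on an aromatic carbon of the furan gives a number 35 percentage points higher from compound 3 to compound 4 (beyond the scatter), so this carbon, next to the ring atom that bears a large group, responds to a one-carbon change, whereas the earlier steps had only swapped the whole group on the saturated ring carbon. The gain is partial: there remains a number 50 percentage points lower from compound 2 to compound 4 (beyond the scatter) and a number 55 percentage points lower from compound 1 to compound 4 (beyond the scatter), so 3-methylfuran-2-yl closes only part of the gap to the two phenyl compounds. Nothing available explains why the methyl raises the number.

The compounds shown leave open whether ethyl, methoxy, chlorine or an amine on the same carbon would carry the number further or lose it. They also leave open whether a methyl elsewhere on the furan would do the same.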